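Removing the Acetyl Group: Compound 2 to Compound 3

The source may report more compounds than this note shows. Statements on the series, on what has been measured and on what is new or still open speak of the compounds shown alone.

Of the compounds shown here, two sharing one core have been measured in an assay on CHO cells for displacement of a labelled ligand from adenosine receptor A3 (Homo sapiens), read by radioligand binding; on this read-out lower numbers stand for stronger inhibition and higher numbers for weaker inhibition. Compound 1 `CCOc1cccc2cc(-c3ccccc3)c(=O)oc12` gives 22500 nM. Within the data shown here, compound 2 `CC(=O)Oc1cccc2cc(-c3ccccc3)c(=O)oc12` gives 6860 nM, the lower of the two numbers, and the only step measured so far, a 3.3-fold lower number from compound 1 to compound 2 (0.52 log units; beyond the scatter), separates them. Compound 3 `O=c1oc2c(O)cccc2cc1-c1ccccc1` has not yet been measured. It differs from compound 2 in one place: hydrogen in place of acetyl on an oxygen on an aromatic ring, so an acetoxy group becomes a hydroxy group. Among the measured compounds shown here, the one measured step, the swap of ethyl for acetyl, changes what sits on that oxygen rather than removing it, so it bears only loosely on the present change, and it was modest. For the measured compounds named here, with no step that leaves the oxygen bare, the expectation for compound 3 is set close to compound 2, as a step of a 1.3-fold higher number from compound 2 to compound 3 (0.12 log units; within the scatter). Compound 3 is therefore estimated at 9000 nM, within a range from 2500 nM to 35000 nM.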

Compound 3, inhibition constant: 5090 nM
For compound 3 the middle estimate is 1.8-fold (0.25 log units) above the measured one, within the range that was stated.
By their numbers in this assay, from the lowest: compounds 3 and 2 (each within the scatter of the next); then compound 1.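

In this assay, replacing acetyl with hydrogen leaves a bare hydroxy group and gives a 1.3-fold lower number from compound 2 to compound 3 (0.13 log units; within the scatter), so this assay does not separate acetoxy from hydroxy on this oxygen on an aromatic ring. Replacing ethyl with hydrogen at the same place gives a 4.4-fold lower number from compound 1 to compound 3 (0.65 log units; beyond the scatter), and together with the earlier ethyl-to-acetyl step this sets ethyl apart from both other groups among these three compounds. No measurement of any other kind is available here to explain this outcome.

Going by these compounds, how a longer chain on this oxygen, or an amine in place of the oxygen, would read in this assay remains open. Also open, on these data alone, is whether these swaps would give the same picture elsewhere on the shared core.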